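A few compounds are considered here, and "the series" means these few. Any claim that something is new, unique, unknown or untested is made for them only; others in the source may bear on it.

Measured compounds:
compound 1 `COc1ccc(-c2ccc3c(c2)oc(=O)n3C(=O)NCCCCc2ccccc2)cc1`: 67 nM
compound 2 `O=C(NCCCCc1cccs1)n1c(=O)oc2ccccc21`: 37 nM
compound 3 `O=C(NCCCCc1ccccc1)n1c(=O)oc2cc(Cl)c(Cl)cc21`: 18 nM

In an assay on HEK293 cells for inhibition of acid ceramidase (Homo sapiens), with a stated time of 10 min (on this read-out lower numbers stand for stronger inhibition and higher numbers for weaker inhibition), compound 1 gives the highest of the three numbers. Compound 2 lies close to it, within the usual scatter, so no order between those two can be read. Compound 3 sits clearly lower, beyond the scatter, so compound 3 inhibits more strongly than compound 1.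

Compound 4 `O=C(NCCCCc1ccccc1)n1c(=O)oc2cc([N+](=O)[O-])ccc21` has not yet been measured. Its structure differs from compound 1 in one place: nitro in place of 4-methoxyphenyl on an aromatic carbon. The other compounds show that a smaller group on the shared core does not weaken inhibition, since compound 3 gives 18 nM. A modest step toward a lower number is therefore expected in this assay, a 2.4-fold lower number from compound 1 to compound 4 (0.38 log units; beyond the scatter), though it may fall within the scatter. Compound 4 is estimated at 28 nM, between 9 nM and 85 nM.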

Compound 4, half-maximal inhibitory concentration: 3 nM
Beside the measured number, compound 4's estimate is 9.3-fold (0.97 log units) above it; the measured number lies below the stated range.
By their numbers in this assay, from the lowest: compound 4; then compound 3; then compounds 2 and 1 (each within the scatter of the next).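

In this assay, within the data shown here, replacing 4-methoxyphenyl with nitro on this aromatic carbon gives a 22-fold lower number from compound 1 to compound 4 (1.35 log units; beyond the scatter), so a single change at this position can shift inhibition strongly, something the earlier compounds, which differ in more than one place, could not show. Nothing given here explains the size of this step. On these data alone, it remains open whether the gain comes from having nitro here or simply from losing the 4-methoxyphenyl. An amine or a nitrile on the same carbon would help separate these two readings.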